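Carbamate aryl variation on the shared core, PANC-1 inhibition

A few compounds are considered here, and "the series" means these few. Any claim that something is new, unique, unknown or untested is made for them only; others in the source may bear on it.

Measured so far:
compound 1 `CC(C)=CCC1Cc2c(OCc3ccccc3)cc(=O)n(CCCO)c2CC1(C)C` — -0.3%
compound 2 `CC(C)=CCC1Cc2c(OC(=O)Nc3cccc(F)c3)cc(=O)n(CCCO)c2CC1(C)C` — 66.1%
compound 3 `CC(C)=CCC1Cc2c(OC(=O)Nc3ccc(F)c(Cl)c3)cc(=O)n(CCCO)c2CC1(C)C` — 79.8%

In a functional assay on PANC-1 cells (Homo sapiens) for inhibition, read by MTT assay, with a stated time of 24 h, tested at 10 uM (a lower number here means less inhibition, a higher number more inhibition at the concentration tested (going by the name of the read-out)), compound 3 stands highest of the three, with compound 2 nearest and compound 1 furthest behind it. Compound 4 `CC(C)=CCC1Cc2c(OC(=O)Nc3ccc(Cl)cc3)cc(=O)n(CCCO)c2CC1(C)C` differs from compound 3 by 4-chlorophenyl in place of 3-chloro-4-fluorophenyl on an amide-type nitrogen. The only measured step at this position is a number 13.7 percentage points higher from compound 2 to compound 3 (beyond the scatter), a modest gain when the aryl group on the amide-type nitrogen was changed; both carbamates sit far above compound 1, as shown by a number 66.4 percentage points higher from compound 1 to compound 2 (beyond the scatter) and a number 80.1 percentage points higher from compound 1 to compound 3 (beyond the scatter). Swapping one substituted aryl for another is therefore expected to move the read-out only modestly, most likely down and possibly within the scatter: a number 9.8 percentage points lower from compound 3 to compound 4 (within the scatter). Compound 4 is estimated at 70%, range 55% to 85%.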

Compound 4, a percentage reported as inhibition, at one concentration (the size of the read-out at that concentration, not a potency): 49.8%
Compound 4: middle estimate off by 20.2 percentage points, on the high side; measured number outside the range, below it.
By their numbers in this assay, from the lowest: compound 1; then compound 4; then compound 2; then compound 3.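

In this assay, the aryl group on the amide-type nitrogen carries more weight than the earlier carbamates showed: a number 30 percentage points lower from compound 3 to compound 4 (beyond the scatter), and a number 16.3 percentage points lower from compound 2 to compound 4 (beyond the scatter), so 4-chlorophenyl sits below both fluorine-bearing aryl groups. The carbamate nonetheless keeps a clear gain over benzyl on the oxygen, with a number 50.1 percentage points higher from compound 1 to compound 4 (beyond the scatter). Nothing at hand accounts for the drop.

Still open, from the compounds shown here alone, is whether an unsubstituted phenyl or a 4-methoxyphenyl on the amide-type nitrogen would stay with these carbamates. A 4-fluorophenyl would help separate the contributions of the two halogens.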